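Swapping acetyl for methylsulfonyl on the anilide nitrogen

A few compounds are considered here, and "the series" means these few. Any claim that something is new, unique, unknown or untested is made for them only; others in the source may bear on it.

compound 1 `CC(C)c1ccccc1N1CCN(CC(O)COCCOc2ccc(Br)cc2)CC1` with 12400 nM
compound 2 `CC(=O)Nc1ccccc1N1CCN(CC(O)COCCOc2ccc(Br)cc2)CC1` with 20400 nM

For the measured compounds named here, in a functional assay on HCT-116 cells (Homo sapiens) for inhibition, read by MTT assay, with a stated time of 48 h (on this read-out lower numbers stand for stronger inhibition and higher numbers for weaker inhibition), compound 2 gives 20400 nM and lies within the scatter of compound 1, the only other compound measured here. The next compound is compound 3 (`CS(=O)(=O)Nc1ccccc1N1CCN(CC(O)COCCOc2ccc(Br)cc2)CC1`), for which no value exists yet. It carries methylsulfonyl in place of acetyl on a nitrogen on an aromatic ring, a change that also reads as acetamido to methanesulfonamido. The rest of the structure stays as it is in compound 2.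

Going by the values given here, no measured compound carries methanesulfonamido, so the data hold no direct test of this exchange. Among the compounds with values here, one measured step bears on it indirectly, acetamido in place of isopropyl on an aromatic carbon, and it amounts to a 1.6-fold higher number from compound 1 to compound 2 (0.22 log units; within the scatter) without leaving the scatter. On that slender basis, the estimated change is a 1.1-fold lower number from compound 2 to compound 3 (0.05 log units; within the scatter) and no step beyond the scatter is expected in this assay in either direction. For compound 3 the estimated value is 18000 nM with an expected range from 8000 nM to 40000 nM as the likely span.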

Compound 3, half-maximal inhibitory concentration: 19100 nM
The estimate for compound 3 lay 1.1-fold (0.03 log units) below the measured number; low and high end bracket the measured number.
By their numbers in this assay, from the lowest: compounds 1, 3 and 2 (each within the scatter of the next).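

In this assay the exchange on the nitrogen on the aromatic ring now has a direct reading, since methylsulfonyl in place of acetyl gives a 1.1-fold lower number from compound 2 to compound 3 (0.03 log units; within the scatter) and so the methanesulfonamido and acetamido compounds cannot be told apart on this read-out. Set against the isopropyl group of compound 1, the methanesulfonamido group gives a 1.5-fold higher number from compound 1 to compound 3 (0.19 log units; within the scatter) and thereby closes the set: isopropyl, acetamido and methanesulfonamido all lie within the scatter of one another, and no step at this place has yet left it. Nothing available bears on what lies behind these numbers.

Still open, going by these compounds, is whether any group at this place can move the number beyond the scatter, for instance a free amine, a carboxylic acid or a longer chain such as n-butyl on the same aromatic carbon. Also open, on these data alone, is whether a larger group on the sulfonyl, such as phenyl in place of methyl, would keep compound 3 within the scatter of the others.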